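Removing the Ester from the Nitrophenyl Triazole Amide

A few compounds are considered here, and "the series" means these few. Any claim that something is new, unique, unknown or untested is made for them only; others in the source may bear on it.

Three compounds have been measured in a functional assay on BMDM cells (Mus musculus, strain C57BL/6) for inhibition, with a stated time of 2 days; a lower number here means a stronger inhibitor, a higher number a weaker inhibitor:

compound 1 `Cc1csc(NC(=O)Cn2cc(-c3ccncc3)nn2)n1`: 100 nM
compound 2 `CCOC(=O)c1sc(NC(=O)Cn2cc(-c3ccc([N+](=O)[O-])cc3)nn2)nc1C`: 1840 nM
compound 3 `CCOC(=O)c1sc(NC(=O)Cn2cc(-c3ccncc3)nn2)nc1C`: 120 nM

Compound 3 and compound 1 carry the same pyridin-4-yl group on the shared core and differ in one place, (hydrogen in place of ethoxycarbonyl on an aromatic carbon). That change gave a 1.2-fold lower number from compound 3 to compound 1 (0.08 log units; within the scatter), so the two compounds behave alike in this assay.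

Compound 2 differs from compound 3 in another place, (4-nitrophenyl in place of pyridin-4-yl on an aromatic carbon). Here the step is a 15-fold lower number from compound 2 to compound 3 (1.19 log units; beyond the scatter), and compound 2 stands with the highest number among the three measured compounds, beyond the scatter from both others.

The unmeasured compound 4 `Cc1csc(NC(=O)Cn2cc(-c3ccc([N+](=O)[O-])cc3)nn2)n1` keeps the 4-nitrophenyl group of compound 2 and differs from compound 2 by hydrogen in place of ethoxycarbonyl on an aromatic carbon. Within the data shown here, this is the same change that separates compound 3 from compound 1, at a place described in the same words, so the only guide is that earlier step. Because a 1.2-fold lower number from compound 3 to compound 1 (0.08 log units; within the scatter) stayed within the scatter, the step from compound 2 to compound 4 is expected to be small as well, about a 1.2-fold lower number from compound 2 to compound 4 (0.09 log units; within the scatter). Compound 4 is therefore estimated at 1500 nM in this assay, with a likely range from 600 nM to 4000 nM. This rests on one comparison only, and a single pair cannot show whether the change behaves the same way beside a 4-nitrophenyl group.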

Compound 4, half-maximal inhibitory concentration: 190 nM
Compound 4: the middle estimate sits 7.9-fold (0.90 log units) above what was measured; measured number below the stated range.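

In this assay, putting hydrogen in place of ethoxycarbonyl on the compounds carrying the 4-nitrophenyl group gave a 9.7-fold lower number from compound 2 to compound 4 (0.99 log units; beyond the scatter), so a change that made no clear difference in the pair carrying the pyridin-4-yl group made a clear difference here. The size of this step therefore did not carry over from one core to the other: the same change on two cores in this assay, a 1.2-fold lower number (0.08 log units; within the scatter) from compound 3 to compound 1 and a 9.7-fold lower number (0.99 log units; beyond the scatter) from compound 2 to compound 4, 8.1-fold (0.91 log units) apart, beyond the scatter of two such steps This shows that, in this series, a step read from one pair cannot simply be applied to another pair, but two pairs do not show why the steps differ or what size of step a further core would give.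

The compounds shown leave open what other groups on that aromatic carbon would do on either core, such as a carboxylic acid, an amide or an ester with a longer chain. They also leave open whether a plain phenyl group or a pyridin-3-yl group, in place of 4-nitrophenyl or pyridin-4-yl, would go with the small step or the large one when ethoxycarbonyl is replaced by hydrogen.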